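The compounds below may be only part of what the source reports. "The series", "measured", "known", "first", "only" and "open" are said of these compounds alone.

Measured compounds:
Compound 1, `O=C(CC1c2ccccc2N=C(SCCCCCN2CCCC2)N1c1ccc(-c2ccccc2)cc1)NCc1ccc(F)cc1`: 276000 nM
Compound 2, `O=C(CC1c2ccccc2N=C(SCCCCCN2CCCC2)N1c1ccc(-c2ccc(F)cc2)cc1)NCc1ccc(F)cc1`: 4880 nM

Both were tested in an assay on cells for inhibition of Voltage-dependent T-type calcium channel subunit alpha-1H (Homo sapiens), read by patch clamp; a lower number here means a stronger inhibitor, a higher number a weaker inhibitor. Compound 1 holds the highest of the two numbers, that is, the weaker position; its nearest neighbour is compound 2, and the step of a 57-fold lower number from compound 1 to compound 2 (1.75 log units; beyond the scatter) came from a fluoro in place of hydrogen on an aromatic carbon, at the far end of the shared core, turning phenyl into 4-fluorophenyl.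

The step now followed goes the other way and at another place. Compound 3, `O=C(CC1c2ccccc2N=C(SCCCCCN2CCCC2)N1c1ccc(-c2ccccc2)cc1)NCc1ccccc1`, differs from compound 1 by hydrogen in place of fluoro on an aromatic carbon: the 4-fluorobenzyl of the amide becomes benzyl, so (4-fluorobenzyl)amino becomes benzylamino. Going by the values given here, no measured step touches this position. Among the compounds with values here, the only guidance is the step from compound 1 to compound 2, where adding a fluoro elsewhere lowered the number strongly; taking a fluoro away here may therefore be expected to raise it, if anything, but with little certainty about size. The expectation for compound 3 is a modest rise, a 1.6-fold higher number from compound 1 to compound 3 (0.21 log units; within the scatter). The estimated value for compound 3 is 450000 nM, within a range of 120000 nM to 1800000 nM, with a fair chance that this assay reports only a limit.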

Compound 3, half-maximal inhibitory concentration: 6900 nM
For compound 3 the middle estimate is 65-fold (1.81 log units) above the measured one; the whole stated range lies above it.
By their numbers in this assay, from the lowest: compounds 2 and 3 (each within the scatter of the next); then compound 1.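

In this assay, going by these compounds alone, replacing the fluoro of the 4-fluorobenzyl group with hydrogen to give benzyl brings a 40-fold lower number from compound 1 to compound 3 (1.60 log units; beyond the scatter) and shows that this position, which no earlier step touched, can respond strongly to a change of a single atom. Within this pair, the fluoro belongs to the weaker inhibitor, whereas the fluoro added at the far end of the shared core belongs to the stronger inhibitor in the step to compound 2, so a fluoro does not push the number in one direction at both places. Compound 1 therefore stands out among these three compounds, since the number falls beyond the scatter with either single change away from it. Nothing available here accounts for the size or direction of this change.

The compounds shown leave open whether the strong response is particular to hydrogen or would also appear with chloro, methoxy or a nitrile at the same place on the benzyl ring. They also leave open what a compound carrying both the 4-fluorophenyl end and the plain benzyl amide would give, and whether the two changes would add together.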